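Bromine on the core of a weak adenosine receptor binder

The source may hold more compounds than are shown below. What is called first, only, known or untested is meant among the compounds shown, and "the series" means these compounds.

Compound 1, `O=C(CCc1ccccc1)Nc1nc2ccccc2c(=O)s1`, gives 365 nM.
Compound 2, `O=C(CCCc1ccccc1)Nc1nc2ccccc2c(=O)s1`, gives > 1000 nM, which is a limit of the assay.
Compound 3, `O=C(CCc1ccccc1Br)Nc1nc2ccccc2c(=O)s1`, gives > 1000 nM, which is a limit of the assay.

All three were run in an assay on CHO cells for displacement of a labelled ligand from adenosine receptor A2b (Homo sapiens), read by scintillation counting, with a stated time of 75 min; a higher number here means a weaker inhibitor, a lower number a stronger inhibitor. Two of the values sit at the limit of > 1000 nM in this assay, at which 2 of the 3 values shown sit. Going from compound 1 to compound 2 the change is benzyl in place of phenyl on a saturated chain carbon, two bonds along the chain from a carbonyl carbon, and the result is an at least 2.7-fold higher number from compound 1 to compound 2 (0.43 log units; beyond the scatter). Going from compound 1 to compound 3 the change is bromo in place of hydrogen on an aromatic carbon, and the result is an at least 2.7-fold higher number from compound 1 to compound 3 (0.43 log units; beyond the scatter). Between compound 2 and compound 3 there is a step that the two limits leave unreadable from compound 2 to compound 3, since both sit at a limit.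

Compound 4, `O=C(CCCc1ccccc1)Nc1nc2ccc(Br)cc2c(=O)s1`, has not yet been measured in this assay. It differs from compound 2 by bromo in place of hydrogen on an aromatic carbon. Among the measured compounds shown here, this is the same kind of change as the one from compound 1 to compound 3, but not the same: in compound 3 the bromo sits on a six-membered aromatic ring of carbon only, ortho to a large group, while in compound 4 it sits on a ring that is part of a fused or bridged system of two rings, meta to a fused ring and para to a fused ring.

The expected step is a step that the limit leaves unreadable from compound 2 to compound 4. This rests on compound 2 already sitting at a limit, > 1000 nM. It also rests on the earlier bromo step, an at least 2.7-fold higher number from compound 1 to compound 3 (0.43 log units; beyond the scatter). For compound 4 the estimate in this assay is 3000 nM, with a range from 1000 nM to 15000 nM, and most likely the assay will again report only a limit.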

Compound 4, inhibition constant: > 1000 nM
Compound 4 ended at the assay's limit (the forecaster's own chance of this, stated with the estimate: 85%); the middle value lies beyond the limit too.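

In this assay, compound 4 gives > 1000 nM, which is a limit of the assay. Compound 2 sits at the same limit, so the step from compound 2 to compound 4 cannot be read: the limit of > 1000 nM in this assay, at which 3 of the 4 values shown sit.

The compounds shown leave open the true values of compound 2 and compound 4, and so whether bromo in place of hydrogen on the shared core changes binding at all.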